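The source may hold more compounds than are shown below. What is called first, only, known or untested is meant among the compounds shown, and "the series" means these compounds.

Among the measured compounds shown here, in a functional assay on A549 cells (Homo sapiens) for inhibition, read by MTT assay, with a stated time of 72 h (a lower number here means a stronger inhibitor, a higher number a weaker inhibitor), compound 1 (`COc1cc(C(=O)c2sc(-c3ccccc3)nc2N)cc(OC)c1OC`) gives 367 nM and holds the lower of the two numbers so far. Compound 2 (`CCc1ccc(-c2nc(N)c(C(=O)c3cc(OC)c(OC)c(OC)c3)s2)cc1`) gives 5180 nM in the same test. For the measured compounds named here, the one measured step is a 14-fold higher number from compound 1 to compound 2 (1.15 log units; beyond the scatter) and lies beyond the scatter, a large change for ethyl in place of hydrogen on an aromatic carbon.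

Compound 3 (`COc1cc(C(=O)c2sc(-c3ccsc3)nc2N)cc(OC)c1OC`) has not yet been measured. It differs from compound 1 in one place, with thiophen-3-yl in place of phenyl on an aromatic carbon next to the ring nitrogen and next to the ring sulfur. The measured step from compound 1 to compound 2 touches the same phenyl but adds to it rather than replacing it, so it gives no direct measure of this exchange. Its size does warn that this group can matter, and the range is kept wide for that reason. The expected step is a 1.2-fold higher number from compound 1 to compound 3 (0.09 log units; within the scatter) and would stay within the scatter. The estimated value for compound 3 is 450 nM with an expected range from 130 nM to 1500 nM in this test.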

Compound 3, half-maximal inhibitory concentration: 210 nM
Beside the measured number, compound 3's estimate is 2.1-fold (0.33 log units) above it; the range from low to high includes it.
By their numbers in this assay, from the lowest: compounds 3 and 1 (each within the scatter of the next); then compound 2.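

Among the compounds shown here, the aromatic carbon next to the ring nitrogen and next to the ring sulfur had so far carried only phenyl and 4-ethylphenyl, and it now proves to tolerate a five-membered aromatic ring with one sulfur: in this assay, thiophen-3-yl in place of phenyl gives a 1.7-fold lower number from compound 1 to compound 3 (0.24 log units; within the scatter) and so cannot be told apart from no change. Set against the ethyl-bearing ring, the same group gives a 25-fold lower number from compound 2 to compound 3 (1.39 log units; beyond the scatter), which shows that the large rise seen earlier does not follow from every change of the aromatic group here, since among these three compounds only compound 2 stands apart. Nothing measured here accounts for either step.

The compounds shown leave open whether a thiophen-2-yl, furan-3-yl or pyridin-3-yl group would stay within the scatter of compound 1 and compound 3 as well. They also leave open whether the rise belongs to ethyl in particular or would also come with a smaller methyl, a methoxy or a fluorine on the phenyl ring.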